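A few compounds are considered here, and "the series" means these few. Any claim that something is new, unique, unknown or untested is made for them only; others in the source may bear on it.

Values in an ADME assay on a cell-free system (plasma, Rattus norvegicus) for protein binding:

- compound 1 `O=C(NOC[C@H](O)CO)c1ccc2cnsc2c1Nc1ccc(I)cc1F`: 99.2%
- compound 2 `O=C(NOCCO)c1ccc2[nH]ncc2c1Nc1ccc(I)cc1F`: 96.1%

Of these two compounds, compound 2 carries the larger unbound fraction, and its gap to compound 1 lies beyond the scatter. The two differ in more than one place, so their values give no direct reading of any single change.

The next compound to be measured is compound 3 `O=C(NOCCO)c1ccc2[nH]ncc2c1Nc1ccc(Br)cc1F`. It departs from compound 2 in one place only: bromo in place of iodo on an aromatic carbon. This is bromo in place of iodo on an aromatic carbon, meta to a fluoro group and para to a large group; the rest of the structure is unchanged.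

Within the data shown here, no measured pair shows this exchange, so the expectation is cautious and starts from compound 2 at 96.1%. A small shift towards more free compound is expected in this assay, not beyond the scatter. The estimated change is a 1.3-fold higher unbound fraction from compound 2 to compound 3 (0.11 log units; within the scatter). For compound 3 the expected value is 95%, with an estimated range of 91% to 97.5%.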

Compound 3, plasma protein binding: 96.5%
Compound 3: the middle estimate sits 1.4-fold (0.15 log units) (unbound fraction) above what was measured; the range from low to high includes it.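

In this assay, among these compounds, the exchange of 2-fluoro-4-iodophenyl for 4-bromo-2-fluorophenyl gives the first reading of a single change, and the step a 1.1-fold lower unbound fraction from compound 2 to compound 3 (0.05 log units; within the scatter) shows that bromo and iodo cannot be told apart at this carbon, meta to a fluoro group and para to a large group. The earlier pair of compound 1 and compound 2 could not show this, as those two differ in more than one place, so the gap between them cannot be assigned to any single change, and this exchange does not account for it on the evidence of compound 2 and compound 3 alone. No available information bears on why the exchange leaves the read-out within the scatter.

Whether this carbon tolerates any change in this read-out remains open, as only two heavy halogens are shown here and a chloro, a methyl or a nitrile in the same place could read differently. Also open, on these data alone, is whether bromo in place of iodo reads the same on the core and side chain of compound 1, where so little of the compound is free.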